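Hydroxy to methoxy on compound 1

A few compounds are considered here, and "the series" means these few. Any claim that something is new, unique, unknown or untested is made for them only; others in the source may bear on it.

In a functional assay on NCI-H322M cells (Homo sapiens) for antiproliferative activity, read by sulforhodamine B assay, with a stated time of 48 h (a lower number here means a stronger inhibitor of growth, a higher number a weaker inhibitor of growth), compound 1 `O=C(NCCCNc1cc(-c2cn(-c3ccccc3)nc2-c2cccc(O)c2)ccn1)Nc1ccc(F)cc1` gives 12400 nM and compound 2 `O=C(NCCCNc1cc(-c2cn(-c3ccccc3)nc2-c2cccc(O)c2)ccn1)Nc1cccc(C(F)(F)F)c1` gives 9320 nM so the two sit level. Within the data shown here, the only measured step is a 1.3-fold lower number from compound 1 to compound 2 (0.12 log units; within the scatter) and it lies within the scatter. Among the measured compounds shown here, compound 1 therefore has no clear position above or below its sole neighbour on these numbers.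

Compound 3 `COc1cccc(-c2nn(-c3ccccc3)cc2-c2ccnc(NCCCNC(=O)Nc3ccc(F)cc3)c2)c1` keeps the core of compound 1 and differs by methyl in place of hydrogen on an oxygen on an aromatic ring which reads as hydroxy to methoxy, or 3-hydroxyphenyl to 3-methoxyphenyl. The measured step lies at a different place on the molecule, so it bears on this change only indirectly. For the measured compounds named here, no measured pair compares hydroxy with methoxy, and the direction of any shift is open. On this thin evidence, no step beyond the scatter is expected in this assay and the uncertainty stays wide. The estimated step is a 1.1-fold higher number from compound 1 to compound 3 (0.05 log units; within the scatter) with no firm direction behind it. For compound 3 the estimated value is 14000 nM with an expected range from 5500 nM to 35000 nM in this read-out.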

Compound 3, concentration for total growth inhibition: > 37000 nM
Compound 3: a limit, no number; the forecaster's own chance of this, stated with the estimate: 10%; at least 2.6-fold (0.42 log units) between middle value and limit.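

In this assay, among these compounds, the change from 3-hydroxyphenyl to 3-methoxyphenyl gives an at least 2.9-fold higher number from compound 1 to compound 3 (0.47 log units; beyond the scatter), so this position on the shared core responds to a change of a single heavy atom, whereas the only earlier step, a 1.3-fold lower number from compound 1 to compound 2 (0.12 log units; within the scatter), made at a different place, stayed within the scatter. Compound 3 gives > 37000 nM, which is a limit and not a number. The direction of the hydroxy to methoxy step can therefore be read from this pair, with a weaker inhibitor of growth on the methoxy side, but its full size cannot: the limit of > 37000 nM in this assay, at which 1 of the 3 values shown sits.

The compounds shown leave open whether the shift follows from losing the hydrogen on the oxygen or from adding the methyl, a question that an amine or a fluorine in place of the hydroxy would help to separate. Also open, from the compounds shown here alone, is whether the same change has a like effect with 3-(trifluoromethyl)phenyl in place of 4-fluorophenyl, as on compound 2, since this single pair is the whole basis for the reading.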